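Swapping the hydrazone aryl group on an adenosine-derived ligand

The source may hold more compounds than are shown below. What is called first, only, known or untested is meant among the compounds shown, and "the series" means these compounds.

Measured compounds:
Compound 1 `CC(/C=N/Nc1nc(N)c2ncn([C@@H]3O[C@H](CO)[C@@H](O)[C@H]3O)c2n1)Cc1ccc(C(C)C)cc1` gives 9500 nM in an assay on CHO-K1 cells for displacement of a labelled ligand from adenosine receptor A1 (Homo sapiens), read by scintillation counting, with a stated time of 60 min; on this read-out higher numbers stand for weaker inhibition and lower numbers for stronger inhibition.
Compound 2 `Nc1nc(N/N=C/c2ccc3ncccc3c2)nc2c1ncn2[C@@H]1O[C@H](CO)[C@@H](O)[C@H]1O` gives 9.8 nM in this assay.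

Of these two, compound 2 has the lower inhibition constant, and its gap to compound 1 lies beyond the scatter. Compound 3 `Nc1nc(N/N=C/c2ccc(Br)cn2)nc2c1ncn2[C@@H]1O[C@H](CO)[C@@H](O)[C@H]1O` arises from compound 2 by one change: 5-bromopyridin-2-yl in place of quinolin-6-yl on a carbon with a double bond to nitrogen. Among the measured compounds shown here, only two compounds are known here, so the effect of this change is uncertain; the aromatic ring kept on the hydrazone carbon suggests compound 3 stays well away from compound 1. A moderate weakening is expected, as the step of a 6.1-fold higher number from compound 2 to compound 3 (0.79 log units; beyond the scatter) shows. For compound 3 the expected inhibition constant is 60 nM, within 10 nM to 400 nM.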

Compound 3, inhibition constant: 4.7 nM
Estimate against measurement, compound 3: 13-fold (1.11 log units) above; measured number outside the range, below it.
By their numbers in this assay, from the lowest: compound 3; then compound 2; then compound 1.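

Replacing quinolin-6-yl with 5-bromopyridin-2-yl on this carbon gives a 2.1-fold lower number from compound 2 to compound 3 (0.32 log units; beyond the scatter) in this assay. At this position, then, a single aromatic ring carrying bromine can do modestly better than the larger two-ring quinolin-6-yl, so the second ring is not needed for strong inhibition. Nothing shown here explains the gain. From the compounds shown here alone, whether it comes from the bromine or from where the ring nitrogen sits remains open. A plain pyridin-2-yl, or a 5-chloropyridin-2-yl, on the same carbon would help separate these two.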